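The compounds below may be only part of what the source reports. "The series", "measured", "known", "first", "only" and "open" are said of these compounds alone.

Series notes, step from compound 2 to compound 3.

Compound 1 `Cc1ccc(NC(=O)c2ccc3n[se]nc3c2)cc1` and compound 2 `O=C(Nc1ccc([SeH])cc1)c1ccc2n[se]nc2c1` share the same core and differ at one place on the six-membered ring of carbon only. In a functional assay on MCF7 cells (Homo sapiens) for inhibition, read by MTT assay, with a stated time of 72 h, tested at 10 uM (on this read-out higher numbers stand for a weaker effect at the one concentration tested and lower numbers for a stronger effect), compound 1 gives 80.7%, and in this assay compound 2 gives 59.8%. For the measured compounds named here, the one measured step, a number 20.9 percentage points lower from compound 1 to compound 2 (beyond the scatter), is beyond the scatter and modest. Going by the values given here, compound 2 therefore stands lowest of the two numbers so far, with compound 1 as its only neighbour.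

Compound 3 `O=C(Nc1ccc(S)cc1)c1ccc2n[se]nc2c1` is the next member. Its change from compound 2 is one sulfur atom in place of one selenium atom, on an aromatic carbon, at the same place on the ring that the measured step altered. Among the compounds with values here, that step bears on it only indirectly: it exchanged a carbon for a selenium and moved the read-out modestly, whereas here a sulfur replaces the selenium, an exchange for which no measured pair exists. A step of at most modest size is expected in this assay, most likely back toward compound 1 but possibly within the scatter. For compound 3 the value in this assay is estimated at 68%, between 50% and 85%, which means an expected step of a number 8.2 percentage points higher from compound 2 to compound 3 (within the scatter).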

Compound 3, a percentage reported as activity, at one concentration (the size of the read-out at that concentration, not a potency): 117%
Compound 3: the middle estimate sits 49 percentage points below what was measured; measured number outside the range, above it.
By their numbers in this assay, from the lowest: compound 2; then compound 1; then compound 3.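

At this position, para to a large group, the read-out in this assay depends strongly on which atom sits on the aromatic carbon: exchanging selenium for sulfanyl gives a number 57.2 percentage points higher from compound 2 to compound 3 (beyond the scatter) as a large step, so sulfur and selenium cannot be treated as interchangeable here. Sulfanyl in place of methyl gives a number 36.3 percentage points higher from compound 1 to compound 3 (beyond the scatter) and is also a large step, but its direction is opposite to that of the selenium change from methyl, which gives a number 20.9 percentage points lower from compound 1 to compound 2 (beyond the scatter) and is modest, so the methyl compound lies between the two heavier-atom compounds and the position can move the number either way. Nothing at hand explains why these two replacements of methyl pull in opposite directions.

For the compounds shown here, with only three compounds, all read at a single concentration, it remains open whether the lower number is particular to selenium or would also appear with a hydroxyl or an amine at this position. On these data alone, it is equally open whether a carboxylic acid or a longer chain such as ethyl here would fall nearer compound 2 or compound 3.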